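A few compounds are considered here, and "the series" means these few. Any claim that something is new, unique, unknown or untested is made for them only; others in the source may bear on it.

Three compounds have so far been measured in an assay on isolated protein for inhibition of leukotriene C4 synthase (Homo sapiens), read by LC-MS, with stated times of 45 min and 20 min; a higher number here means a weaker inhibitor, a lower number a stronger inhibitor:

compound 1, `COc1cc(N(CC2CC2)c2cc(C(F)(F)F)ccc2F)cnc1C(=O)[C@H]1C[C@@H]1C(=O)O`, at 14 nM
compound 2, `COc1cc(N(CC2CC2)c2cc(Cl)c(F)cc2F)cnc1C(=O)[C@H]1C[C@@H]1C(=O)O`, at 27.6 nM
compound 3, `COc1cc(N(CC(C)C)c2cc(C(F)(F)F)ccc2F)cnc1C(=O)[C@H]1C[C@@H]1C(=O)O`, at 6.8 nM

Compound 3 differs from compound 1 by isopropyl in place of cyclopropyl on a saturated chain carbon bound to a nitrogen on an aromatic ring, and this change gave a 2.1-fold lower number from compound 1 to compound 3 (0.31 log units; beyond the scatter). Compound 2 and compound 1 share most of their structure, but the difference between the two cores is not broken down here; in this assay the value of compound 2 lies within the usual scatter of that of compound 1, while compound 3 stands apart from compound 2 beyond the scatter.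

Compound 4, `COc1cc(N(CC(C)C)c2cc(Cl)c(F)cc2F)cnc1C(=O)[C@H]1C[C@@H]1C(=O)O`, is not yet measured. It differs from compound 2 by isopropyl in place of cyclopropyl on a saturated chain carbon bound to a nitrogen on an aromatic ring, which is the same change as that made from compound 1 to compound 3, at the same place. Because that change gave a 2.1-fold lower number from compound 1 to compound 3 (0.31 log units; beyond the scatter), the step expected here is a 2.1-fold lower number from compound 2 to compound 4 (0.33 log units; beyond the scatter), with the starting point being the value of compound 2, 27.6 nM. Compound 4 is thus estimated at 13 nM in this assay, with a likely range from 6 nM to 28 nM.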

Compound 4, half-maximal inhibitory concentration: 8.5 nM
Beside the measured number, compound 4's estimate is 1.5-fold (0.18 log units) above it, within the range that was stated.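

On the core of compound 2, isopropyl in place of cyclopropyl again lowered the number in this assay, giving a 3.2-fold lower number from compound 2 to compound 4 (0.51 log units; beyond the scatter), so the change ran the same way on both cores. The size of the two steps cannot be told apart: the same change on two cores in this assay, a 2.1-fold lower number (0.31 log units; beyond the scatter) from compound 1 to compound 3 and a 3.2-fold lower number (0.51 log units; beyond the scatter) from compound 2 to compound 4, 1.6-fold (0.20 log units) apart, within the scatter of two such steps. This shows that the change carried over between these two cores, but two pairs are all there is, so it shows neither that the step would hold on any other core nor what lies behind it.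

Only cyclopropylmethyl and isobutyl appear at this place, which leaves open how a longer chain or a chain ending in an amine would read on either core. Every compound shown also keeps the same carboxylic acid, so it remains open whether the step would survive with an amide or a tetrazole there instead.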